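The compounds below may be only part of what the source reports. "The series", "measured", "known", "first", "only" and "open" are said of these compounds alone.

Among the compounds with values here, in a functional assay on MCF7 cells (Homo sapiens) for cytotoxicity, read by MTT assay, with a stated time of 72 h, tested at 1 uM (on this read-out higher numbers stand for more inhibition of growth at the one concentration tested and lower numbers for less inhibition of growth), the two measured members stand well apart. Compound 1 `Cc1ccnc(/C(N)=N/NC(=S)N2CCOCC2)c1` gives 1.22% in this assay, while compound 2 `Cc1ccnc(/C(N)=N/NC(=S)N2CCN(c3ccccn3)CC2)c1` gives 21% in this assay. Compound 1 therefore holds the lowest of the two numbers, and its nearest neighbour, compound 2, sits higher by a gap beyond the usual scatter of this read-out.

Compound 3 `Cc1ccnc(/C(N)=N/NC(=S)N2CCCC2)c1` has not yet been measured in this assay. It differs from compound 1 in one place: pyrrolidin-1-yl in place of morpholin-4-yl on a thiocarbonyl carbon. Within the data shown here, no measured pair in this set spans exactly this change, so the size of the step is open. Because compound 1 gives only 1.22% in this assay, and the exchange keeps a small saturated ring on the thiocarbonyl carbon, a step of only modest size, if any beyond the scatter, is expected, and compound 3 is estimated to reach 5% in this assay, within a range from -8% to 18%. The step of a number 3.8 percentage points higher from compound 1 to compound 3 (within the scatter) is thus expected to be small and upward at most.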

Compound 3, percent growth inhibition at one concentration: 49%
Compound 3: middle estimate off by 44 percentage points, on the low side, and the stated range ends below it.
By their numbers in this assay, from the lowest: compound 1; then compound 2; then compound 3.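

In this assay, pyrrolidin-1-yl in place of morpholin-4-yl on a thiocarbonyl carbon gives a large rise, a number 47.8 percentage points higher from compound 1 to compound 3 (beyond the scatter), so this place is far from indifferent to which small saturated ring it carries. The earlier compounds shown here could not show this, and keeping a saturated ring at this place evidently does not keep the read-out unchanged. The change alters ring size and removes the ring oxygen in one step, and nothing available explains why the read-out moves so far.

The compounds shown leave open whether the smaller ring or the loss of the oxygen accounts for the step, a question that piperidin-1-yl, a six-membered ring without oxygen, would address. Also open, from the compounds shown here alone, is how an open-chain amine such as dimethylamino would fare at this place.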